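This account rests on a few compounds, and the source may have more. Where it says the series, first, only, none or still open, it means among the compounds named here.

In a functional assay on MCF7 cells (Homo sapiens) for antiproliferative activity, read by CellTiter-Glo, with a stated time of 5 days (a lower number here means a stronger inhibitor, a higher number a weaker inhibitor), compound 1 (`CC1=C(c2cccc(O)c2)[C@H](c2ccc(OC[C@H](C)N3CC[C@@H](C)C3)cc2)Oc2ccc(O)cc21`) gives 0.1 nM. Compound 2 (`CC1=C(c2ccc(C#N)cc2)C(c2ccc(OC[C@H](C)N3CC[C@@H](C)C3)cc2)Oc2ccc(O)cc21`) gives 10 nM, the higher of the two numbers and beyond the scatter. Within the data shown here, these two compounds differ in more than one place, so the data offer no single-change step as a guide. Compound 3 (`CC1=C(c2ccc(F)cc2)C(c2ccc(OC[C@H](C)N3CC[C@@H](C)C3)cc2)Oc2ccc(O)cc21`) comes from compound 2 by one change, fluoro in place of cyano on an aromatic carbon. A modest move to a lower number is expected, perhaps not beyond the scatter, with the estimated step being a 2.0-fold lower number from compound 2 to compound 3 (0.30 log units; within the scatter). The estimate for compound 3 is 5 nM, with an expected range of 1 nM to 25 nM.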

Compound 3, half-maximal inhibitory concentration: 0.4 nM
For compound 3 the middle estimate is 13-fold (1.10 log units) above the measured one; the measured number lies below the stated range.
By their numbers in this assay, from the lowest: compound 1; then compound 3; then compound 2.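

In this assay, replacing cyano with fluoro on this aromatic carbon, para to a large group, gives a 25-fold lower number from compound 2 to compound 3 (1.40 log units; beyond the scatter). This first single-change step shows that the number responds strongly to the group at this position, since exchanging one small substituent carries it well beyond the scatter. Nothing available explains the size of this step. As far as these compounds go, whether chloro, methyl or methoxy at the same carbon would give a number closer to that of fluoro or of cyano remains open. So does the effect of the same exchange on a different core.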